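Compound 4 in a Gonadotropin-Releasing Hormone Receptor Series

The source may hold more compounds than are shown below. What is called first, only, known or untested is meant among the compounds shown, and "the series" means these compounds.

Compound 1, `COc1ccc(C(C)=O)cc1CSc1nc2cc(NC(=O)C3CC3)ccc2n1C(C)C`, gives 260 nM in an assay on isolated protein for inhibition of Gonadotropin-releasing hormone receptor (Homo sapiens); on this read-out lower numbers stand for stronger inhibition and higher numbers for weaker inhibition. Compound 2, `COc1ccc(C#N)cc1CSc1nc2cc(NC(=O)C3CC3)ccc2n1C(C)C`, gives 570 nM. Compound 3, `COc1ccc([N+](=O)[O-])cc1CSc1nc2cc(NC(=O)NC(C)(C)C)ccc2n1C1CC1`, gives 79 nM.

Compound 3 stands lowest of the three, with compound 1 nearest and compound 2 furthest; it is the most potent measured compound. Compound 4, `CCCCCn1c(SCc2cc([N+](=O)[O-])ccc2OC)nc2cc(NC(=O)NC(C)(C)C)ccc21`, differs from compound 3 by pentyl in place of cyclopropyl on an aromatic nitrogen. Within the data shown here, the single measured step, a 2.2-fold higher number from compound 1 to compound 2 (0.34 log units; beyond the scatter), concerns a group on an aromatic carbon and does not bear on the ring nitrogen; no measured step addresses this change. Compound 4 is therefore expected to remain close to compound 3. For compound 4 the expected step is a 1.5-fold higher number from compound 3 to compound 4 (0.18 log units; within the scatter). The estimate for compound 4 is 120 nM, with a range from 40 nM to 360 nM.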

Compound 4, half-maximal inhibitory concentration: 210 nM
The estimate for compound 4 lay 1.8-fold (0.24 log units) below the measured number, and the stated range covers the measured number.
By their numbers in this assay, from the lowest: compound 3; then compounds 4 and 1 (each within the scatter of the next); then compound 2.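

At the aromatic nitrogen, pentyl in place of cyclopropyl gives a 2.7-fold higher number from compound 3 to compound 4 (0.42 log units; beyond the scatter) in this assay. Among these compounds, this is the first measured change at this position, and it shows that an open chain with no ring weakens inhibition here, though only modestly. On these data alone, whether a propyl chain, a cyclohexyl ring or a pentyl chain ending in an amine on this nitrogen would match cyclopropyl stays open. Nothing available explains why this step has the size it does.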